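This account rests on a few compounds, and the source may have more. Where it says the series, first, only, none or still open, it means among the compounds named here.

Two compounds of the series have numbers in a functional assay on HepG2 cells (Homo sapiens) for antiproliferative activity, read by MTT assay, with a stated time of 96 h; a lower number here means a stronger inhibitor of growth, a higher number a weaker inhibitor of growth. Compound 1 `Cc1cc(-c2ccc(F)cc2)n(Cc2ccc(C(=O)NO)cc2)n1` gives 3630 nM. Compound 2 `O=C(CCCNC(=O)c1cc(-c2ccc(F)cc2)[nH]n1)NO` gives 88000 nM, the higher of the two numbers, and its gap to compound 1 lies beyond the usual scatter of repeated measurements. Compound 3 `O=C(CCCCCNC(=O)c1cc(-c2ccc(F)cc2)[nH]n1)NO` has not yet been measured. Relative to compound 2 the change is 2-(hydroxycarbamoyl)ethyl in place of hydroxycarbamoyl on a saturated chain carbon, three bonds along the chain from an amide-type nitrogen. Going by the values given here, no measured pair of the series shows this step, so its size is open. Compound 2 stands at the weak end of what is known, and in compound 3 the 2-(hydroxycarbamoyl)ethyl enters on a saturated chain carbon, three bonds along the chain from an amide-type nitrogen; a move toward the lower number of compound 1, beyond the scatter, is expected rather than a loss. For compound 3 the estimate in this assay is 12000 nM, with a range of 2500 nM to 60000 nM. This expected step is a 7.3-fold lower number from compound 2 to compound 3 (0.87 log units; beyond the scatter).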

Compound 3, concentration for 50% growth inhibition: 47600 nM
Compound 3: the middle estimate sits 4.0-fold (0.60 log units) below what was measured, and the stated range covers the measured number.
By their numbers in this assay, from the lowest: compound 1; then compounds 3 and 2 (each within the scatter of the next).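

In this assay, going by these compounds alone, the first reading at this position is a 1.8-fold lower number from compound 2 to compound 3 (0.27 log units; within the scatter), for 2-(hydroxycarbamoyl)ethyl in place of hydroxycarbamoyl on a saturated chain carbon, three bonds along the chain from an amide-type nitrogen. On this evidence, the added length of chain does not separate compound 3 from compound 2, so this single change gives no measurable gain or loss in growth inhibition. No independent measurement bears on the reason for this result.

Open, on these data alone, is whether a longer chain at this carbon would give a step beyond the scatter, or whether this pair simply sits on a flat stretch of chain length. Also open, as far as these compounds go, is how a carboxylic acid in place of hydroxycarbamoyl would read on the same chain.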